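Notes on compound 4: amino in place of methyl

The source may hold more compounds than are shown below. What is called first, only, known or untested is meant among the compounds shown, and "the series" means these compounds.

The series is read in a physicochemical assay for lipophilicity, read by HPLC, measured as octanol-water partition, at pH 7.2; a lower number here means a more polar compound, a higher number a more lipophilic compound. Compound 1 `N#Cc1ccc(NC(=O)Nc2ccc(F)c(C(F)(F)F)c2)cc1` gives 3.8, compound 2 `CC(=O)c1ccc(NC(=O)Nc2ccc(F)c(C(F)(F)F)c2)cc1` gives 3.6, and compound 3 `O=C(Nc1cnccn1)Nc1cnccn1` gives 0.8. Compound 2 stands second highest of the three numbers: its nearest neighbour is compound 1, whose number lies within the scatter of it, and its furthest is compound 3, well beyond the scatter below it. For the measured compounds named here, the one single-place step measured, a number 0.20 log units lower from compound 1 to compound 2 (within the scatter), is within the scatter.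

Compound 4 `NC(=O)c1ccc(NC(=O)Nc2ccc(F)c(C(F)(F)F)c2)cc1` differs from compound 2 at one place: amino in place of methyl on a carbonyl carbon. Going by the values given here, no measured pair covers amino in place of methyl on a carbonyl carbon, so the step from compound 1 to compound 2 bears on it only as a neighbouring change at the same carbon, and that step was small. The change, as counted, adds one hydrogen-bond donor, and the expectation in this assay is a step downward beyond the scatter, a number 1.00 log units lower from compound 2 to compound 4 (beyond the scatter). Compound 4 is therefore estimated at 2.6, with a range from 2.1 to 3.1.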

Compound 4, distribution coefficient: 2.7
Compound 4: middle estimate off by 0.10 log units, on the low side; the measured number falls inside the stated range.
By their numbers in this assay, from the lowest: compound 3; then compound 4; then compounds 2 and 1 (each within the scatter of the next).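

In this assay this position proves sensitive to the group it carries: the new compound gives a number 0.90 log units lower from compound 2 to compound 4 (beyond the scatter) and a number 1.10 log units lower from compound 1 to compound 4 (beyond the scatter) against a number 0.20 log units lower from compound 1 to compound 2 (within the scatter) for the earlier exchange. For the compounds shown here, the earlier compounds showed only a change within the scatter at this aromatic carbon, whereas carbamoyl is the first group there to move the number beyond it, with amino in place of methyl on the carbonyl carbon entering one hydrogen-bond donor as counted. Nothing on hand speaks to the origin of this step.

The compounds shown leave open whether the step follows the amide hydrogens or the nitrogen itself, a question that a methylamino or dimethylamino group on the same carbonyl carbon could address. Going by these compounds, how a carboxylic acid or a longer chain at that carbon would read also remains open.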